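Chlorination of a fused core and cell tolerance

The source may report more compounds than this note shows. Statements on the series, on what has been measured and on what is new or still open speak of the compounds shown alone.

Measured so far:
Compound 1, `ClCc1cccc(Cn2cnc3ncnc(Cl)c32)c1`: 46800 nM
Compound 2, `ClCc1cccc(Cn2cnc3c(Cl)ncnc32)c1`: 26300 nM
Compound 3, `ClCc1cccc(Cn2cnc3c(Cl)nc(Cl)nc32)c1`: 61700 nM

Three compounds share a benzyl-chloride side arm and differ in their fused core. In a functional assay on OVCAR-4 cells (Homo sapiens) for cytotoxicity, read by sulforhodamine B assay, with a stated time of 48 h (a lower number here means that less compound is tolerated, a higher number that more compound is tolerated), compound 1 gives 46800 nM, compound 2 gives 26300 nM and compound 3 gives 61700 nM. Compound 1 and compound 2 have the same atoms joined differently; the difference between the two cores is not broken down here, and their values lie within the scatter of each other. Compound 1 and compound 3 also fall within the scatter of one another.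

Among the measured compounds shown here, the one counted step is chloro in place of hydrogen on an aromatic carbon, which moved the number by a 2.3-fold higher number from compound 2 to compound 3 (0.37 log units; beyond the scatter), a modest rise beyond the scatter.

Compound 4, `ClCc1cccc(Cn2cnc3nc(Cl)nc(Cl)c32)c1`, has not yet been measured in this assay. It differs from compound 1 by chloro in place of hydrogen on an aromatic carbon, and the place of the change is described in the same words as for compound 2 and compound 3, so it is the same change on the other core. Because a 2.3-fold higher number from compound 2 to compound 3 (0.37 log units; beyond the scatter) was modest, compound 4 is expected to sit somewhat higher than compound 1, at a 2.1-fold higher number from compound 1 to compound 4 (0.33 log units; beyond the scatter), though the cores are not identical and the outcome may differ. Compound 4 is therefore estimated at 100000 nM, likely between 40000 nM and 250000 nM.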

Compound 4, concentration lethal to 50% of the cells: 5370 nM
Estimate against measurement, compound 4: 19-fold (1.27 log units) above, and the stated range ends above it.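

Chloro in place of hydrogen on an aromatic carbon, here between two ring nitrogen atoms, gave an 8.7-fold lower number from compound 1 to compound 4 (0.94 log units; beyond the scatter) in this assay, so the number fell on this core, whereas the same change had raised it on the other. The result of this change therefore did not carry over from one core to the other, and the two steps run in opposite directions by a gap larger than the scatter of two such steps: the same change on two cores in this assay, a 2.3-fold higher number (0.37 log units; beyond the scatter) from compound 2 to compound 3 and an 8.7-fold lower number (0.94 log units; beyond the scatter) from compound 1 to compound 4, 20-fold (1.31 log units) apart, beyond the scatter of two such steps

Among the compounds shown here, this shows that, within this series, the outcome of the change depends on the core that carries it, but it rests on only two pairs of compounds and does not show which feature of the cores is responsible, or whether the same split would appear in any other measurement.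

The compounds shown carry only hydrogen or chloro at this place, which leaves open how an amine, a methoxy group or a thiol there would read on either core. From the compounds shown here alone, all of them also keep the benzyl chloride side arm, so it remains open how the two cores would compare with a hydroxymethyl group or a longer chain in place of the chloromethyl group.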